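From methyl to methoxy: a small step expected

The compounds below may be only part of what the source reports. "The series", "measured", "known", "first", "only" and "open" are said of these compounds alone.

In a functional assay on HSC-4 cells (Homo sapiens) for cytotoxicity, with a stated time of 24 h (a lower number here means that less compound is tolerated, a higher number that more compound is tolerated), compound 1 `CN(C)c1ccc(/C=C2\CCC/C(=C\c3ccccc3[N+](=O)[O-])C2=O)cc1` gives > 400000 nM as a limit of the assay and not a number. Among the compounds with values here, compound 2 `Cc1ccc(/C=C2\CCC/C(=C\c3ccccc3[N+](=O)[O-])C2=O)cc1` stands at 40000 nM as the only true number so far. Compound 3 `COc1ccc(/C=C2\CCC/C(=C\c3ccccc3[N+](=O)[O-])C2=O)cc1` carries methoxy in place of methyl on an aromatic carbon. Within the data shown here, the one measured step that bears on it is an at least 10-fold lower number from compound 1 to compound 2 (1.00 log units; beyond the scatter) and, resting on a limit (the limit of > 400000 nM in this assay, at which 1 of the 2 values shown sits), it gives only a loose scale for a different pair of groups. In this assay a small rise, not clearly beyond the scatter, is therefore expected. The expected change is a 1.8-fold higher number from compound 2 to compound 3 (0.24 log units; within the scatter) in all. Compound 3 is estimated at 70000 nM within a range of 25000 nM to 250000 nM here.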

Compound 3, half-maximal cytotoxic concentration: 24000 nM
For compound 3 the middle estimate is 2.9-fold (0.46 log units) above the measured one; measured number outside the range, below it.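

Exchanging 4-methylphenyl for 4-methoxyphenyl gives a 1.7-fold lower number from compound 2 to compound 3 (0.22 log units; within the scatter), so the added oxygen leaves compound 2 and compound 3 indistinguishable in this assay. The gap seen with methyl also appears with methoxy, which gives an at least 16-fold lower number from compound 1 to compound 3 (1.22 log units; beyond the scatter), so it does not depend on methyl alone. This step still rests on a limit, not a number: the limit of > 400000 nM in this assay, at which 1 of the 3 values shown sits.

Going by these compounds, how far dimethylamino truly lies from the other two groups remains open. On these data alone, it is also open whether a primary amine, a hydroxyl or a carboxylic acid on this aromatic carbon would read like methyl and methoxy or like dimethylamino.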